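Methyl to fluoro on the anilino ring: expected effect

The source may hold more compounds than are shown below. What is called first, only, known or untested is meant among the compounds shown, and "the series" means these compounds.

Measured so far:
- compound 1, `Cc1ccc(Nc2cncc(N3CC4CC(C3)N4)c2)cc1`: 0.148 nM
- compound 2, `c1ccc(Nc2ccc(N3CC4CC(C3)N4)cn2)cc1`: 2.66 nM

Two compounds of the series have numbers in an assay on cell membranes for displacement of a labelled ligand from Neuronal acetylcholine receptor; alpha4/beta2 (Rattus norvegicus); a higher number here means a weaker inhibitor, a lower number a stronger inhibitor. Compound 1 gives 0.148 nM and has the lowest number of the two. Among the compounds with values here, compound 2, whose structure is `c1ccc(Nc2ccc(N3CC4CC(C3)N4)cn2)cc1`, gives 2.66 nM; the gap between the two lies beyond the scatter, and as the two cores differ in more than one place no single step connects them.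

Compound 3, `Fc1ccc(Nc2cncc(N3CC4CC(C3)N4)c2)cc1`, has not yet been measured. It differs from compound 1 by fluoro in place of methyl on an aromatic carbon, in words fluoro in place of methyl on an aromatic carbon, para to a large group on a six-membered aromatic ring of carbon only. Both groups are single heavy atoms with no donors or acceptors. Within the data shown here, no measured pair shows this exchange, so there is nothing in the data to set its size. The expectation is a step from compound 1 to compound 3 of a 2.0-fold higher number from compound 1 to compound 3 (0.31 log units; beyond the scatter) in this assay, hardly beyond the scatter and, if anything, toward a higher number.

Compound 3 is therefore estimated at 0.3 nM in this assay, with a range from 0.1 nM to 1 nM.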

Compound 3, inhibition constant: 0.091 nM
For compound 3 the middle estimate is 3.3-fold (0.52 log units) above the measured one, and the stated range ends above it.
By their numbers in this assay, from the lowest: compounds 3 and 1 (each within the scatter of the next); then compound 2.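

Fluoro in place of methyl, para to a large group on the six-membered aromatic ring of carbon only, gives in this assay a step of a 1.6-fold lower number from compound 1 to compound 3 (0.21 log units; within the scatter) and is the only single-place comparison in the series so far. Compound 1 and compound 3 therefore cannot be ordered, and this position takes either group without a separable change in the number, something compound 2 could not show as it differs from compound 1 in more than one place. No measurement at hand bears on why the two groups read alike.

On these data alone, what hydrogen, chloro, methoxy, trifluoromethyl or a carboxylic acid would do at this same place on the core of compound 1 remains open, so the reach of this tolerance beyond methyl and fluoro is unknown. Also open, as far as these compounds go, is whether the 4-methylphenyl to 4-fluorophenyl exchange reads the same on the core of compound 2, or in any assay other than this assay.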